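The compounds below may be only part of what the source reports. "The series", "measured", "known", "first", "only" and "open" are said of these compounds alone.

The compounds measured so far:

Compound 1, `Cc1ccc(NC(=O)c2c(NO)cc(-c3ccc(C)cc3)oc2=O)cc1`. In an ADME assay on Huh-7 cells (Homo sapiens) for cytotoxicity, read by a luciferase reporter and WST assay, with a stated time of 3 days (a lower number here means that less compound is tolerated, a higher number that more compound is tolerated), compound 1 gives > 20000 nM, which is a limit of the assay.
Compound 2, `O=C(NCCO)c1c(NO)cc(-c2ccccc2)oc1=O`. In this assay compound 2 gives > 20000 nM, again a limit of the assay.
Compound 3, `O=C(NCCO)c1c(NO)cc(-c2ccc(F)cc2)oc1=O`. In this assay compound 3 gives > 20000 nM, also a limit of the assay.

Compound 3 thus stands where every compound of the set stands: at the limit of > 20000 nM in this assay, at which 3 of the 3 values shown sit. Going by the values given here, no number separates it from compound 1 or compound 2, and the one step between neighbours, a step that the two limits leave unreadable from compound 2 to compound 3, cannot be read because both of its ends are limits.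

The step now followed goes from compound 3 to compound 4, `Cc1ccc(-c2cc(NO)c(C(=O)NCCO)c(=O)o2)cc1`, and the change is methyl in place of fluoro on an aromatic carbon. Among the compounds with values here, the only measured step that touches this part of the molecule is the unreadable one from compound 2 to compound 3, so nothing among the measured values shows that a single-atom swap on that ring moves the read-out of this assay at all. Since all three measured compounds sit at the same limit, compound 4 is expected to sit there too, with an estimated step that the limit leaves unreadable from compound 3 to compound 4 and an estimated value of 30000 nM, between 15000 nM and 100000 nM.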

Compound 4, half-maximal cytotoxic concentration: > 20000 nM
Compound 4 ended at the assay's limit; the forecaster's own chance of this, stated with the estimate: 85%; the middle value is on the limit's open side.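

In this assay compound 4 gives > 20000 nM, which is a limit of the assay. The steps to compound 4 from compound 1, compound 2 and compound 3 therefore cannot be read, and all four compounds stand together: the limit of > 20000 nM in this assay, at which 4 of the 4 values shown sit.

The compounds shown leave open whether any of these changes moves the half-maximal cytotoxic concentration at all.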